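Compound 1 to compound 4: one added hydroxy

This account rests on a few compounds, and the source may have more. Where it says the series, first, only, none or still open, it means among the compounds named here.

In an ADME assay on MDCK cells (Canis lupus familiaris) for cytotoxicity (on this read-out lower numbers stand for higher toxicity in this test and higher numbers for lower toxicity in this test), compound 1 `O=[N+]([O-])C1=CNc2nc(C(F)(F)F)nn2C1c1ccc(O)c(O)c1` gives 1210000 nM, the higher of the two numbers, while compound 3 `O=[N+]([O-])C1=CNc2nc(C(F)(F)F)nn2C1O` gives 33000 nM. Compound 2 `O=[N+]([O-])C1=CNc2nc(-c3ccco3)nn2C1c1ccc(O)c(O)c1` has only a limit, > 1200000 nM. Compound 4 `O=[N+]([O-])C1=CNc2nc(C(F)(F)F)nn2C1c1ccc(O)c(O)c1O` differs from compound 1 by hydroxy in place of hydrogen on an aromatic carbon. For the measured compounds named here, two measured steps bear on this only indirectly: a step that the limit leaves unreadable from compound 1 to compound 2 changes another part of the molecule, and a 37-fold lower number from compound 1 to compound 3 (1.56 log units; beyond the scatter) removes the whole 3,4-dihydroxyphenyl group. Neither tests a hydroxy added to that group, so no step beyond the scatter is expected in this assay, with a slight lean towards a lower number. The estimated step is a 1.5-fold lower number from compound 1 to compound 4 (0.18 log units; within the scatter). For compound 4 the expected value is 800000 nM, with an estimated range of 300000 nM to 1500000 nM.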

Compound 4, half-maximal cytotoxic concentration: 373000 nM
For compound 4 the middle estimate is 2.1-fold (0.33 log units) above the measured one; the measured number falls inside the stated range.
By their numbers in this assay, from the lowest: compound 3; then compound 4; then compound 1.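

In this assay, hydroxy in place of hydrogen on this aromatic carbon, ortho to a hydroxy group and ortho to a large group, gives a 3.2-fold lower number from compound 1 to compound 4 (0.51 log units; beyond the scatter). A single added oxygen on the ring therefore shifts the number beyond the scatter, so this position is not silent, although the step is modest. Nothing shown gives a cause for this step.

As far as these compounds go, whether an amine, a methoxy or a chlorine at this position would give a similar step remains open. So does whether the same hydroxy has a similar effect on the furan-2-yl analogue.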